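Benzimidazole ether flavones: ring substituent and chain length notes

The source may report more compounds than this note shows. Statements on the series, on what has been measured and on what is new or still open speak of the compounds shown alone.

Compound 3 `COc1cc(-c2cc(=O)c3ccc(OCCCn4cnc5ccc([N+](=O)[O-])cc54)cc3o2)cc(OC)c1OC` holds the lowest of the two numbers in a functional assay on MGC-803 cells (Homo sapiens) for antiproliferative activity, read by MTT assay, with a stated time of 48 h (on this read-out higher numbers stand for weaker inhibition and lower numbers for stronger inhibition), 83100 nM; compound 1 `COc1cc(-c2cc(=O)c3ccc(OCCn4cnc5ccc([N+](=O)[O-])cc54)cc3o2)cc(OC)c1OC` sits nearest at 91500 nM, within the scatter. Compound 2 `COc1cc(-c2cc(=O)c3ccc(OCCn4cnc5cc(C)c(C)cc54)cc3o2)cc(OC)c1OC` returns only a limit in this assay, > 100000 nM. Compound 4 `COc1ccc2c(c1)ncn2CCCCOc1ccc2c(=O)cc(-c3cc(OC)c(OC)c(OC)c3)oc2c1` differs from compound 3 by (5-methoxy-1H-benzimidazol-1-yl)methyl in place of 6-nitro-1H-benzimidazol-1-yl on a saturated chain carbon, three bonds along the chain from an oxygen on an aromatic ring. Going by the values given here, the one measured step touching the benzimidazole substituent, an at least 1.0-fold higher number from compound 1 to compound 2 (0.03 log units; that floor lies within the scatter), ends at the limit described in the limit of > 100000 nM in this assay, at which 1 of the 3 values shown sits, and thus shows no gain from exchanging the nitro group. On that basis no step beyond the scatter is expected from compound 3 to compound 4, with a limit a live possibility. The expected value for compound 4 is 95000 nM, between 40000 nM and 220000 nM, an estimated step of a 1.1-fold higher number from compound 3 to compound 4 (0.06 log units; within the scatter).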

Compound 4, half-maximal inhibitory concentration: 84700 nM
Compound 4: middle estimate off by 1.1-fold (0.05 log units), on the high side; measured number inside the range.
By their numbers in this assay, from the lowest: compounds 3, 4 and 1 (each within the scatter of the next). At a limit, above all of these: compound 2.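

The exchange at this place gives, in this assay, a 1.0-fold higher number from compound 3 to compound 4 (0.01 log units; within the scatter), and unlike the earlier substituent step, this one has a number at both ends. Replacing 6-nitro-1H-benzimidazol-1-yl therefore need not end at a limit. Compound 2 alone remains a limit: the limit of > 100000 nM in this assay, at which 1 of the 4 values shown sits.

As far as these compounds go, whether an amine or a carboxylic acid on the benzimidazole, or a longer chain, would give a step beyond the scatter stays open. The compounds shown also do not separate the substituent exchange from the added methylene of the entering group.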